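This account rests on a few compounds, and the source may have more. Where it says the series, first, only, none or still open, it means among the compounds named here.

Measured compounds and their numbers:

Compound 1 `Cc1cc(F)ccc1S(=O)(=O)N1CCN(c2ccc(C(=O)NCc3ccc(F)cc3)nn2)CC1` gives 0.25 h in an ADME assay on microsomes from liver (Mus musculus) for metabolic stability, read by LC-MS, using NADPH, tested at 10 uM; a lower number here means that the compound disappears faster, a higher number that the compound lasts longer.
Compound 2 `Cc1ccccc1S(=O)(=O)N1CCN(c2ccc(C(=O)NCc3cncs3)nn2)CC1` gives 0.3 h in this assay.
Compound 3 `N#Cc1ncccc1S(=O)(=O)N1CCN(c2ccc(C(=O)NCc3ccc(F)cc3)nn2)CC1` gives 0.0833 h in this assay.

Among these three, compound 3 stands at the bottom: its half-life is shorter than that of the other two, and both gaps are beyond the usual scatter. The new compound, compound 4 `Cc1ccccc1S(=O)(=O)N1CCN(c2ccc(C(=O)NCc3ccc(F)cc3)nn2)CC1`, has not yet been measured. It differs from compound 3 in one place: 2-methylphenyl in place of 2-cyanopyridin-3-yl on a sulfonyl sulfur.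

For the measured compounds named here, one measured step bears directly on this change, and it runs the other way: a 3.0-fold lower number from compound 1 to compound 3 (0.48 log units; beyond the scatter). Compound 4 also carries the same 2-methylphenyl on the sulfonyl sulfur as compound 2, whose half-life in this assay is close to that of compound 1. Putting a plain 2-methylphenyl back in place of the 2-cyanopyridin-3-yl is therefore expected to undo the drop seen going to compound 3, giving a longer half-life for compound 4, a step of about a 3.0-fold higher number from compound 3 to compound 4 (0.48 log units; beyond the scatter).

For compound 4 the expected half-life in this assay is 0.25 h, with a range from 0.12 h to 0.5 h.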

Compound 4, half-life: 0.433 h
Compound 4: middle estimate off by 1.7-fold (0.24 log units), on the low side; the measured number falls inside the stated range.
By their numbers in this assay, from the lowest: compound 3; then compounds 1, 2 and 4 (each within the scatter of the next).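

In this assay, 2-methylphenyl in place of 2-cyanopyridin-3-yl on the sulfonyl sulfur gives a 5.2-fold higher number from compound 3 to compound 4 (0.72 log units; beyond the scatter) and so shows that this change, with nothing else altered, moves the half-life by more than the scatter. Hydrogen in place of fluoro on an aromatic carbon gives a 1.7-fold higher number from compound 1 to compound 4 (0.24 log units; within the scatter) and so leaves the drop at compound 3 as no product of the fluoro group that compound 1 carries, since the step up from compound 3 appears without that group as well. At the other end of the molecule, 4-fluorophenyl in place of 1,3-thiazol-5-yl on a saturated chain carbon bound to an amide-type nitrogen gives a 1.4-fold higher number from compound 2 to compound 4 (0.16 log units; within the scatter) and so, for this pair, that swap does not separate the two compounds.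

Nothing here explains why compound 3 has the shortest half-life of the set. Also open, going by these compounds, is whether the nitrile or the ring nitrogen of the 2-cyanopyridin-3-yl group matters more, a question that a 2-cyanophenyl or a plain pyridin-3-yl on the sulfonyl sulfur could answer in this assay.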